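This account rests on a few compounds, and the source may have more. Where it says the series, first, only, none or still open, it means among the compounds named here.

Of the compounds shown here, three sharing one core have been measured in a functional assay on MCF7 cells (Homo sapiens) for cytotoxicity, read by MTT assay, with a stated time of 48 h; a lower number here means a stronger inhibitor, a higher number a weaker inhibitor. Compound 1 `COc1ccc(NC(=O)c2cn(-c3ccccc3)nc2-c2ccc(C)cc2)cc1` gives 1620 nM in this assay, the highest of the three numbers, though each gap is within the scatter. Compound 2 `CCOc1ccc(NC(=O)c2cn(-c3ccccc3)nc2-c2ccc(C)cc2)cc1` gives 1030 nM, and compound 3 `CCOc1ccc(NC(=O)c2cn(-c3ccccc3)nc2-c2ccc(OC)cc2)cc1` gives 1100 nM. The step of a 1.6-fold lower number from compound 1 to compound 2 (0.20 log units; within the scatter) comes from a methyl in place of a hydrogen on the chain carbon bound to the aromatic oxygen, and the step of a 1.1-fold higher number from compound 2 to compound 3 (0.03 log units; within the scatter) from a methoxy in place of a methyl on an aromatic carbon.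

Compound 4 `COc1ccc(NC(=O)c2cn(-c3ccccc3)nc2-c2ccc(Cl)cc2)cc1` differs from compound 1 by chloro in place of methyl on an aromatic carbon. Going by the values given here, no measured step covers a chloro at this spot; the nearest comparison is the swap at the same aromatic carbon from compound 2 to compound 3, which stayed within the scatter. On that basis the change is expected to leave this assay roughly unchanged, so the step of a 1.2-fold lower number from compound 1 to compound 4 (0.06 log units; within the scatter) is estimated to fall within the scatter. Compound 4 is therefore expected to give about 1400 nM, with a likely range from 700 nM to 2800 nM.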

Compound 4, half-maximal inhibitory concentration: 1550 nM
Compound 4: the middle estimate sits 1.1-fold (0.04 log units) below what was measured; measured number inside the range.
By their numbers in this assay, from the lowest: compounds 2, 3, 4 and 1 (each within the scatter of the next).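

The change from 4-methylphenyl to 4-chlorophenyl gives a 1.0-fold lower number from compound 1 to compound 4 (0.02 log units; within the scatter) in this assay, so a chloro at this aromatic carbon now has a direct reading. Together with the earlier swap of methyl for methoxy at the same carbon, this makes two different replacements of the methyl, each with a different group on the other side of the molecule, and neither moves the number beyond the scatter. Nothing measured alongside these compounds offers an explanation for this flat result.

On these data alone, it remains open whether any group at this carbon can shift the number beyond the scatter, and an amine, a carboxylic acid or a longer chain such as butyl would test that. As far as these compounds go, whether a chloro here reads the same alongside the ethoxy group of compound 2 also remains open.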